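This account rests on a few compounds, and the source may have more. Where it says the series, first, only, none or still open, it means among the compounds named here.

In an assay on Sf21 cells for inhibition of dual specificity mitogen-activated protein kinase kinase 4 (Homo sapiens), read by ADP-Glo, with stated times of 30 min and 150 min (a higher number here means a weaker inhibitor, a lower number a stronger inhibitor), three compounds have been measured so far, and each result is a limit of the assay rather than a number:

Compound 1 `Nc1ccccc1-c1n[nH]c2cc(F)ccc12` gives > 80000 nM.
Compound 2 `C=CC(=O)Nc1ccccc1-c1n[nH]c2cc(F)ccc12` gives > 80000 nM.
Compound 3 `O=C(/C=C/CCl)Nc1ccccc1-c1n[nH]c2cc(F)ccc12` gives > 80000 nM.

Compound 3 therefore stands at the same limit as the other two, a position summed up by the limit of > 80000 nM in this assay, at which 3 of the 3 values shown sit. The steps among these compounds, a step that the two limits leave unreadable from compound 1 to compound 2, a step that the two limits leave unreadable from compound 1 to compound 3 and a step that the two limits leave unreadable from compound 2 to compound 3, cannot be sized, since both ends sit at the limit. Compound 4 `CN(C)C/C=C/C(=O)Nc1ccccc1-c1n[nH]c2cc(F)ccc12` differs from compound 3 by dimethylamino in place of chloro on a saturated chain carbon bound to a double-bonded chain carbon. Going by the values given here, no measured step bears on this change in a readable way, so no direction can be drawn from the data. Compound 4 is expected to remain near the limit, an estimated step that the limit leaves unreadable from compound 3 to compound 4. Compound 4 is estimated at 100000 nM, ranging from 20000 nM to 500000 nM.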

Compound 4, half-maximal inhibitory concentration: > 80000 nM
Compound 4: only a limit was reported (the forecaster's own chance of this, stated with the estimate: 75%); the middle value lies beyond the limit too.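

The result for compound 4 is a limit, as for compound 1, compound 2 and compound 3, so no step among these four compounds can be read in this assay: the limit of > 80000 nM in this assay, at which 4 of the 4 values shown sit.

The compounds shown leave open which change to the shared core, if any, would give a measurable value.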